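Swapping the pendant phenyl for an aryloxy group

A few compounds are considered here, and "the series" means these few. Any claim that something is new, unique, unknown or untested is made for them only; others in the source may bear on it.

Measured compounds, with their values in a physicochemical assay for acid dissociation:
Compound 1 `c1ccc(-c2ccc3c(NCCCNCc4ccco4)ccnc3c2)cc1` gives 9.47.
Compound 2 `COc1ccc(F)cc1CNCCCNc1ccnc2cc(C3CCCCC3)ccc12` gives 9.47.
Compound 3 `COc1ccc(F)cc1CNCCCNc1ccnc2cc(-c3ccccc3)ccc12` gives 9.47.

Compound 3 stands level with compounds 1 and 2 at the digits shown; all three share the same read-out within the scatter. Two steps lead to it. The step of no change at the digits printed from compound 1 to compound 3 (within the scatter) changes the group on the saturated chain carbon bound to an amine nitrogen. The step of no change at the digits printed from compound 2 to compound 3 (within the scatter) changes the group on the aromatic carbon of the shared core, which is the same position touched now.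

Compound 4 `COc1ccc(F)cc1CNCCCNc1ccnc2cc(Oc3cccc(N(C)C)c3)ccc12` differs from compound 3 as follows:
3-(dimethylamino)phenoxy in place of phenyl on an aromatic carbon

The step from compound 2 to compound 3 bears most directly on this change, since it alters the same aromatic carbon, and it stayed within the scatter. The step from compound 1 to compound 3, at a distant position, also stayed within the scatter. Nothing among these compounds suggests that a substituent at this position moves the acid dissociation constant, so the expected step of no change at the digits printed from compound 3 to compound 4 (within the scatter) is none beyond the scatter. Compound 4 is therefore estimated at 9.47, with a range from 9.1 to 9.8.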

Compound 4, acid dissociation constant: 9.28
Compound 4: the middle estimate sits 0.19 log units above what was measured, within the range that was stated.
By their numbers in this assay, from the lowest: compounds 4, 1, 2 and 3 (each within the scatter of the next).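

In this assay, putting 3-(dimethylamino)phenoxy in place of phenyl gives a number 0.19 log units lower from compound 3 to compound 4 (within the scatter) and so extends the flat picture at this aromatic carbon to a group that holds hydrogen-bond acceptors, which phenyl does not. Setting the same group in place of cyclohexyl gives a number 0.19 log units lower from compound 2 to compound 4 (within the scatter) and leads to the same reading, so the cyclohexyl, phenyl and 3-(dimethylamino)phenoxy groups at this position cannot be told apart in this assay on these numbers. Nothing further is available to explain this outcome, and the finding rests on these values alone.

The compounds shown leave open whether a very different group on this aromatic carbon, such as a carboxylic acid or a primary amine, would move the reading in this assay beyond the scatter. They also do not separate the ether oxygen from the dimethylamino group, so plain phenoxy or a phenyl ring carrying dimethylamino directly would be needed to see what each part contributes on its own.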